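The source may report more compounds than this note shows. Statements on the series, on what has been measured and on what is new or still open speak of the compounds shown alone.

Compound 1, `NC(=O)c1c(NC(=O)c2ccccc2C(F)(F)F)sc2c1CCN(C(=S)Nc1ccccc1Cl)C2`: 17600 nM
Compound 2, `Cc1ccc(C(=O)Nc2sc3c(c2C(N)=O)CCN(C(=S)Nc2ccccc2Cl)C3)cc1`: 8430 nM

Within the data shown here, in a functional assay on HL-60 cells (Homo sapiens) for antiproliferative activity, with a stated time of 24 h (on this read-out lower numbers stand for stronger inhibition and higher numbers for weaker inhibition), compound 2 holds the lowest of the two numbers; the only measured step is a 2.1-fold lower number from compound 1 to compound 2 (0.32 log units; beyond the scatter). Compound 3, `NC(=O)c1c(NC(=O)c2ccncn2)sc2c1CCN(C(=S)Nc1ccccc1Cl)C2`, differs from compound 2 by pyrimidin-4-yl in place of 4-methylphenyl on a carbonyl carbon. Among the measured compounds shown here, that measured step exchanges two other groups at the same carbonyl carbon, so it does not speak directly for this change; it shows only that such an exchange moved the read-out modestly. A modest step is therefore expected, with no clear direction. Compound 3 is estimated at 12000 nM (range 4000 nM to 40000 nM), which is an expected 1.4-fold higher number from compound 2 to compound 3 (0.15 log units; within the scatter).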

Compound 3, half-maximal inhibitory concentration: 34600 nM
Estimate against measurement, compound 3: 2.9-fold (0.46 log units) below, and the stated range covers the measured number.
By their numbers in this assay, from the lowest: compound 2; then compounds 1 and 3 (each within the scatter of the next).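

In this assay, replacing 4-methylphenyl on the carbonyl carbon with pyrimidin-4-yl gives a step beyond the scatter (a 4.1-fold higher number from compound 2 to compound 3 (0.61 log units; beyond the scatter)), so this position does respond to the ring placed there, and this change weakens inhibition. Compared with 2-(trifluoromethyl)phenyl, the same pyrimidin-4-yl group stays within the scatter (a 2.0-fold higher number from compound 1 to compound 3 (0.29 log units; within the scatter)). No measurement shown here accounts for the loss. Going by these compounds, it remains open whether a pyridine ring with a single nitrogen would fall nearer compound 2 or compound 3, and whether a cyclohexyl group or a longer alkyl chain would be tolerated on this carbonyl carbon.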